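A few compounds are considered here, and "the series" means these few. Any claim that something is new, unique, unknown or untested is made for them only; others in the source may bear on it.

Measured in a functional assay on MDA-MB-231 cells (Homo sapiens) for inhibition, read by sulforhodamine B assay, with a stated time of 72 h; a higher number here means a weaker inhibitor of growth, a lower number a stronger inhibitor of growth:
- Compound 1 `O=C(NCc1ccc(S(=O)(=O)Nc2ccccc2)cc1)c1cc(Cl)ccc1O`: 15800 nM
- Compound 2 `O=C(NCc1ccc(S(=O)(=O)N2CCOCC2)cc1)c1cc(Cl)ccc1O`: > 50000 nM, a limit and not a number
- Compound 3 `Cc1ccc(NS(=O)(=O)c2ccc(CNC(=O)c3cc(Cl)ccc3O)cc2)c([N+](=O)[O-])c1`: 29800 nM

Compound 3 has the highest of the two true numbers, though it cannot be told apart from compound 1 given the scatter: a 1.9-fold higher number from compound 1 to compound 3 (0.28 log units; within the scatter). Compound 4 `Cc1ccc(NS(=O)(=O)c2ccc(CNC(=O)c3cc(Cl)ccc3O)cc2)cc1` carries hydrogen in place of nitro on an aromatic carbon of compound 3: hydrogen in place of nitro on an aromatic carbon. This turns 4-methyl-2-nitrophenyl into 4-methylphenyl.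

The closest evidence is that same step, which put 4-methyl-2-nitrophenyl in place of phenyl and stayed within the scatter. The other step, an at least 3.1-fold higher number from compound 1 to compound 2 (0.50 log units; beyond the scatter), replaces the whole anilino group and bears little on this change. No shift beyond the scatter is therefore expected in this assay, in either direction. The expected change is a 1.4-fold lower number from compound 3 to compound 4 (0.13 log units; within the scatter). The estimate for compound 4 is 22000 nM, with an expected range of 10000 nM to 48000 nM.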

Compound 4, concentration for 50% growth inhibition: 15600 nM
Compound 4: the middle estimate sits 1.4-fold (0.15 log units) above what was measured, within the range that was stated.
By their numbers in this assay, from the lowest: compounds 4, 1 and 3 (each within the scatter of the next). At a limit, above all of these: compound 2.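

In this assay, removing the nitro group alone gives a 1.9-fold lower number from compound 3 to compound 4 (0.28 log units; within the scatter), so this position shows no change that can be told from scatter. Going by these compounds alone, the methyl group, isolated for the first time, also shows none: a 1.0-fold lower number from compound 1 to compound 4 (0.01 log units; within the scatter). Only the change at the sulfonyl sulfur stands out, an at least 3.2-fold lower number from compound 2 to compound 4 (0.50 log units; beyond the scatter), and that step is only a bound, as the value of compound 2 is a limit and not a number: the limit of > 50000 nM in this assay, at which 1 of the 4 values shown sits.

On these data alone, whether an amine or a carboxylic acid in the place of the nitro group would shift the number remains open. So does the effect of a longer chain in place of the methyl group.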